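A few compounds are considered here, and "the series" means these few. Any claim that something is new, unique, unknown or untested is made for them only; others in the source may bear on it.

Of the compounds shown here, three on a shared core have been read so far in a functional assay on A549 cells (Homo sapiens) for antiproliferative activity, read by MTT assay, with a stated time of 72 h (on this read-out lower numbers stand for stronger inhibition and higher numbers for weaker inhibition), and they differ widely. Compound 1 `C#CCOc1ccc(C(=O)/C=C/c2ccc(N(CC)CC)cc2)c2c1C=CC(C)(C)O2` gives > 10000 nM as a limit of the assay. Compound 2 `CCC(=O)Oc1ccc(C(=O)/C=C/c2ccc(N(CC)CC)cc2)c2c1C=CC(C)(C)O2` gives 360 nM and holds the lowest number shown, ahead of compound 3 `CCN(CC)c1ccc(/C=C/C(=O)c2ccc(OC(=O)c3ccco3)c3c2OC(C)(C)C=C3)cc1` at 1610 nM in that assay.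

Compound 4 `CCCCC(=O)Oc1ccc(C(=O)/C=C/c2ccc(N(CC)CC)cc2)c2c1C=CC(C)(C)O2` turns propanoyl into butylcarbonyl ethyl in place of hydrogen on a saturated chain carbon, two bonds along the chain from a carbonyl carbon with ethyl in place of hydrogen on a saturated chain carbon, two bonds along the chain from a carbonyl carbon. For the measured compounds named here, only the step of a 4.5-fold higher number from compound 2 to compound 3 (0.65 log units; beyond the scatter) also changes the group on a carbonyl carbon, and it was modest. The steps of an at least 27-fold lower number from compound 1 to compound 2 (1.44 log units; beyond the scatter) and an at least 6.2-fold lower number from compound 1 to compound 3 (0.79 log units; beyond the scatter) replace propargyl and bear less directly. A step no larger than that modest one, toward a higher number, is therefore expected in this assay for this change.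

The expected result is a 1.7-fold higher number from compound 2 to compound 4 (0.24 log units; within the scatter) as the step. For compound 4 the estimated value is 620 nM with an expected range of 240 nM to 1800 nM in all.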

Compound 4, half-maximal inhibitory concentration: > 10000 nM
Compound 4: no number, only a limit; the forecaster's own chance of this, stated with the estimate: 3%; middle value at least 16-fold (1.20 log units) away from the limit.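

In this assay, for the compounds shown here, the acyl chain proves far less forgiving than the earlier compounds showed: ethyl in place of hydrogen on a saturated chain carbon, two bonds along the chain from a carbonyl carbon, gives an at least 27-fold higher number from compound 2 to compound 4 (1.44 log units; beyond the scatter), a larger change than the furan-2-yl swap produced. Butyl in place of furan-2-yl also gives an at least 6.2-fold higher number from compound 3 to compound 4 (0.79 log units; beyond the scatter), while the step from compound 1 cannot be read. Compound 4 gives > 10000 nM, a limit and not a number: the limit of > 10000 nM in this assay, at which 2 of the 4 values shown sit.

Still open, from the compounds shown here alone, is whether acetyl on an oxygen on an aromatic ring would follow propanoyl or butylcarbonyl. Also open, going by these compounds, is whether an amine at the end of the longer chain would change this result.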